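Trifluoromethyl for fluoro on a trimethoxybenzohydrazone

The compounds below may be only part of what the source reports. "The series", "measured", "known", "first", "only" and "open" are said of these compounds alone.

Compound 3 `COc1cc(C(=O)N/N=C/c2cccc(F)c2)cc(OC)c1OC` gives the strongest read-out of the three measured compounds in a functional assay on PC-3 cells (Homo sapiens) for antiproliferative activity, read by MTT assay, tested at 1 uM; on this read-out lower numbers stand for a weaker effect and higher numbers for a stronger effect at the one concentration tested: compound 3 gives 53.5%. Compound 1 `COc1cc(C(=O)N/N=C/c2ccc(F)c(F)c2)cc(OC)c1OC` gives 35.1% in this assay, and compound 2 `COc1cc(C2=NN(C(C)=O)C(c3c(Cl)cccc3Cl)O2)cc(OC)c1OC` gives 5.1%, so compound 3 stands clear of both beyond the scatter. Compound 4 `COc1cc(C(=O)N/N=C/c2cccc(C(F)(F)F)c2)cc(OC)c1OC` is not yet measured. It differs from compound 3 in one place: trifluoromethyl in place of fluoro on an aromatic carbon on an aromatic carbon of a six-membered aromatic ring of carbon only, meta to a large group. Within the data shown here, the only measured step that bears on a change at such an aromatic carbon is a number 18.4 percentage points higher from compound 1 to compound 3 (beyond the scatter), a modest step. Among the measured compounds shown here, no measured pair shows a trifluoromethyl group, so the direction of the new step is not fixed by the data. Compound 4 is therefore expected to stay near compound 3, with a step of about a number 8.5 percentage points lower from compound 3 to compound 4 (within the scatter). The estimate for compound 4 in this assay is 45%, within 20% to 70%.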

Compound 4, a percentage reported as inhibition, at one concentration (the size of the read-out at that concentration, not a potency): 51%
Compound 4: middle estimate off by 6 percentage points, on the low side, and the stated range covers the measured number.
By their numbers in this assay, from the lowest: compound 2; then compound 1; then compounds 4 and 3 (each within the scatter of the next).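

In this assay, the change to trifluoromethyl from fluoro gives a number 2.5 percentage points lower from compound 3 to compound 4 (within the scatter), so at this place, meta to a large group, a group of 4 heavy atoms can enter where 1 left without moving the read-out beyond the scatter. The earlier step, a number 18.4 percentage points higher from compound 1 to compound 3 (beyond the scatter), showed only that hydrogen in place of fluoro on an aromatic carbon could shift the number beyond the scatter; this new pair shows a replacement of fluoro that does not. No measurement shown here bears on why the read-out stays within the scatter across this change.

The compounds shown leave open whether this place would accept a group of another kind, such as an amine, a carboxylic acid or a longer chain. With a single tested concentration, they also leave open whether compound 3 and compound 4 would give a stronger or weaker effect than each other at any other concentration.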